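Swapping Trifluoromethyl for Chloro: An Expected Solubility

A few compounds are considered here, and "the series" means these few. Any claim that something is new, unique, unknown or untested is made for them only; others in the source may bear on it.

In a physicochemical assay for solubility, in phosphate buffer, at pH 7.4 (on this read-out higher numbers stand for higher solubility and lower numbers for lower solubility), compound 1 `CCOC(=O)c1c(-c2ccc(Cl)c(Cl)c2)[nH]c2cc(OC)ccc2c1=O` gives 17000 nM. Compound 2 `CCOC(=O)c1c(-c2ccc(C(F)(F)F)cc2)[nH]c2cc(OC)ccc2c1=O` gives 8000 nM, the lower of the two numbers, and the gap between them lies beyond the usual scatter. Compound 3 `CCOC(=O)c1c(-c2ccc(Cl)cc2)[nH]c2cc(OC)ccc2c1=O` has not yet been measured. It differs from compound 2 by chloro in place of trifluoromethyl on an aromatic carbon, with chloro in place of trifluoromethyl on an aromatic carbon. Going by the values given here, no measured pair shows this change alone, so the expectation is tentative. The expected step, a 1.4-fold higher number from compound 2 to compound 3 (0.14 log units; within the scatter), is a modest rise within the scatter. Compound 3 is expected at 11000 nM, with an estimated range of 5000 nM to 25000 nM.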

Compound 3, solubility: 3000 nM
Estimate against measurement, compound 3: 3.7-fold (0.56 log units) above; the whole stated range lies above it.
By their numbers in this assay, from the lowest: compound 3; then compound 2; then compound 1.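

Within this assay, chloro in place of trifluoromethyl on an aromatic carbon, para to a large group, gives a 2.7-fold lower number from compound 2 to compound 3 (0.43 log units; beyond the scatter), so this position does respond to the change, and the fall lies beyond the scatter. Taking one chloro away and leaving hydrogen gives a 5.7-fold lower number from compound 1 to compound 3 (0.75 log units; beyond the scatter), which places compound 3, with its single chloro, lowest of the three. No measurement shown here accounts for either step. From the compounds shown here alone, whether an amine or a carboxylic acid on this aromatic carbon would lift the number above that of compound 3 remains open.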